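The compounds below may be only part of what the source reports. "The series", "measured", "known", "first", "only" and "open" are said of these compounds alone.

Going by the values given here, in a functional assay on HeLa cells (Homo sapiens) for antiproliferative activity, read by cell counting, with a stated time of 72 h (on this read-out lower numbers stand for stronger inhibition and higher numbers for weaker inhibition), compound 2 `C#C[C@@]1(O)[C@@H](CO)O[C@@H](n2cc(C(F)(F)F)c3c(N)ncnc32)[C@@H]1O` gives 750 nM, the higher of the two numbers so far, while compound 1 `C#C[C@@]1(O)[C@@H](CO)O[C@@H](n2cc(F)c3c(N)ncnc32)[C@@H]1O` gives 150 nM. Compound 3 `C#Cc1cn([C@@H]2O[C@H](CO)[C@](O)(C#C)[C@H]2O)c2ncnc(N)c12` differs from compound 2 by ethynyl in place of trifluoromethyl on an aromatic carbon. Among the compounds with values here, the one measured step that bears on this is trifluoromethyl in place of fluoro, a modest change of a 5.0-fold higher number from compound 1 to compound 2 (0.70 log units; beyond the scatter). Within the data shown here, with only that guide, a modest move toward a lower number is expected in this assay. The estimated step is a 2.5-fold lower number from compound 2 to compound 3 (0.40 log units; beyond the scatter). For compound 3 the expected value is 300 nM, with an estimated range of 60 nM to 1500 nM.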

Compound 3, half-maximal inhibitory concentration: 114000 nM
Estimate against measurement, compound 3: 380-fold (2.58 log units) below; the measured number lies above the stated range.
By their numbers in this assay, from the lowest: compound 1; then compound 2; then compound 3.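

In this assay, going by these compounds alone, ethynyl in place of trifluoromethyl brings a 150-fold higher number from compound 2 to compound 3 (2.18 log units; beyond the scatter) and ethynyl in place of fluoro brings a 760-fold higher number from compound 1 to compound 3 (2.88 log units; beyond the scatter) at this aromatic carbon, so the choice of group here can matter far more than the single earlier step showed. Ethynyl has fewer heavy atoms than trifluoromethyl yet gives the highest number, so the numbers do not follow heavy-atom count from compound 2 to compound 3. Nothing shown gives a reason for this loss. On these data alone, whether the loss belongs to the triple bond itself stays open. So does where a nitrile, a chloro group or an amine on this carbon would stand among these compounds.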